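Dimethylamino for Acetyl on the Core of Compound 1

A few compounds are considered here, and "the series" means these few. Any claim that something is new, unique, unknown or untested is made for them only; others in the source may bear on it.

Measured compounds: compound 1 `COc1cc(C)cc(-c2c(-c3ccnc(-c4ccc(C(C)=O)cc4)c3)cnn2CC#N)c1`, > 100000 nM; compound 2 `Cc1cc(O)cc(-c2nn(CC#N)cc2-c2ccnc(-c3ccc(Oc4ccccc4)cc3)c2)c1`, 24700 nM; compound 3 `Cc1cc(O)cc(-c2nn(CC#N)cc2-c2ccnc(-c3ccc(N(C)C)cc3)c2)c1`, 23400 nM.

Compound 1 was tested in a functional assay on HOP-62 cells (Homo sapiens) for inhibition, read by sulforhodamine B assay, with a stated time of 48 h; a lower number here means a stronger inhibitor of growth, a higher number a weaker inhibitor of growth. For compound 1 the assay returns only a limit, (the limit of > 100000 nM in this assay, at which 1 of the 3 values shown sits), and no number. Compounds 2 and 3 have cores that differ from that of compound 1 elsewhere. In this assay compound 2 gives 24700 nM. In this assay compound 3 gives 23400 nM.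

Compound 4 `COc1cc(C)cc(-c2c(-c3ccnc(-c4ccc(N(C)C)cc4)c3)cnn2CC#N)c1` follows from compound 1 by the change (dimethylamino in place of acetyl on an aromatic carbon). Among the measured compounds shown here, the one measured step that bears on it is the exchange of the group at the same place, a 1.1-fold lower number from compound 2 to compound 3 (0.02 log units; within the scatter), which lies within the scatter. That step leaves a different group and so is only a loose guide; nothing in the measured compounds shows a dimethylamino group moving the read-out far. Compound 4 is therefore expected to stay weak, near the limit of compound 1, with an at least 1.2-fold lower number from compound 1 to compound 4 (0.09 log units; that floor lies within the scatter) as the expected step. The estimate for compound 4 is 80000 nM, between 25000 nM and 250000 nM.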

Compound 4, concentration for total growth inhibition: > 100000 nM
Compound 4: a limit, no number; the forecaster's own chance of this, stated with the estimate: 45%; middle value at least 1.2-fold (0.09 log units) from the limit.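

In this assay compound 4 gives > 100000 nM, a limit and not a number, and compound 1 also sits at a limit, so no step between them can be read: the limit of > 100000 nM in this assay, at which 2 of the 4 values shown sit.

The compounds shown leave open whether dimethylamino in place of acetyl changes growth inhibition on the core of compound 1 at all.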